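Swapping a five-membered heteroaryl for pyridinyl on the thiophene

The source may report more compounds than this note shows. Statements on the series, on what has been measured and on what is new or still open speak of the compounds shown alone.

Compound 2 `O=C1[C@@H](NS(=O)(=O)c2ccc(-c3ccon3)s2)CCN1CCNc1ccncc1` was examined in an assay on isolated protein for inhibition of coagulation factor X (Oryctolagus cuniculus), tested at 1 uM (a higher number here means more inhibition at the concentration tested (going by the name of the read-out), a lower number less inhibition), where compound 2 gives 22%. Compound 1 `O=C1[C@@H](NS(=O)(=O)c2ccc(-c3ccncc3)s2)CCN1Cc1cc2c[nH]ccc-2n1`, which carries a different side chain on the lactam nitrogen, gives 21% in this assay, and the two values lie within the usual scatter of each other, so the pair shows no separation. Compound 3 `O=C1[C@@H](NS(=O)(=O)c2ccc(-c3ccncc3)s2)CCN1CCNc1ccncc1` has not yet been measured in this assay. It differs from compound 2 in one place: pyridin-4-yl in place of 1,2-oxazol-3-yl on an aromatic carbon. The group that enters is the same one that compound 1 carries in the same position, and compound 1 performs much like compound 2 in this assay. No shift beyond the scatter is therefore expected, and the step of no change at the digits printed from compound 2 to compound 3 (within the scatter) is estimated to be small, because compound 1 gives 21% with that group in place. For compound 3, the expected inhibition in this assay is 22%, within a range from 8% to 40%.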

Compound 3, a percentage reported as inhibition, at one concentration (the size of the read-out at that concentration, not a potency): 41%
Compound 3: middle estimate off by 19 percentage points, on the low side, and the stated range ends below it.
By their numbers in this assay, from the lowest: compounds 1 and 2 (each within the scatter of the next); then compound 3.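

With the rest of the molecule unchanged, pyridin-4-yl in place of 1,2-oxazol-3-yl gives a number 19 percentage points higher from compound 2 to compound 3 (beyond the scatter) in this assay, so the group on this aromatic carbon of the five-membered aromatic ring with 1 sulfur does register in the read-out. With pyridin-4-yl held fixed, the group of 8 heavy atoms in place of the group of 9 heavy atoms on the saturated chain carbon gives a number 20 percentage points higher from compound 1 to compound 3 (beyond the scatter) and the change at that second place registers as well. The closeness of compound 1 and compound 2 therefore did not show that either place was without effect, since each change taken alone moves the number.

Nothing at hand accounts for either step. As far as these compounds go, whether a phenyl ring or an amine on that aromatic carbon would hold the number of compound 3 remains open.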